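The compounds below may be only part of what the source reports. "The series", "measured", "known", "first", "only" and "open" are said of these compounds alone.

In a functional assay on DLD-1 cells (Homo sapiens) for cytotoxicity, with a stated time of 48 h (a higher number here means a weaker inhibitor, a lower number a stronger inhibitor), compound 1 `CC(=O)Oc1ccc2oc(/C=C/[S+](C)[O-])cc(=O)c2c1` reports only a limit, > 10000 nM. Compound 2 `CCCC(=O)Oc1ccc2oc(/C=C/[S+](C)[O-])cc(=O)c2c1` gives 8700 nM and compound 3 `CCCCC(=O)Oc1ccc2oc(/C=C/[S+](C)[O-])cc(=O)c2c1` gives 6700 nM, two values within the scatter of each other, so compound 3 stands level with compound 2. Compound 4 `C[S+]([O-])/C=C/c1cc(=O)c2cc(Cl)ccc2o1` carries chloro in place of (butylcarbonyl)oxy on an aromatic carbon. The measured steps only alter the saturated chain on the carbonyl: an at least 1.1-fold lower number from compound 1 to compound 2 (0.06 log units; that floor lies within the scatter), an at least 1.4-fold lower number from compound 1 to compound 3 (0.17 log units; that floor lies within the scatter) and a 1.3-fold lower number from compound 2 to compound 3 (0.11 log units; within the scatter). None of them replaces the whole group, so they are a weak guide, and no change beyond the scatter is expected in this assay. The expected step is a 1.2-fold higher number from compound 3 to compound 4 (0.08 log units; within the scatter). The estimate for compound 4 is 8000 nM, with an expected range from 3500 nM to 20000 nM.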

Compound 4, half-maximal inhibitory concentration: 6500 nM
The estimate for compound 4 lay 1.2-fold (0.09 log units) above the measured number; the range from low to high includes it.
By their numbers in this assay, from the lowest: compounds 4, 3 and 2 (each within the scatter of the next). At a limit, above all of these: compound 1.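

In this assay, swapping the whole ester group on this aromatic carbon for a single chloro atom leaves the number level: a 1.0-fold lower number from compound 3 to compound 4 (0.01 log units; within the scatter) and a 1.3-fold lower number from compound 2 to compound 4 (0.13 log units; within the scatter). So at this position, a group with no carbonyl and no chain does as well as these two esters, while the comparison with the acetoxy compound gives only a floor, an at least 1.5-fold lower number from compound 1 to compound 4 (0.18 log units; that floor lies within the scatter). Compound 1 reports only a limit: the limit of > 10000 nM in this assay, at which 1 of the 4 values shown sits.

As far as these compounds go, whether an amine or a carboxylic acid on this aromatic carbon would move the number beyond the scatter remains open. So does whether a longer chain on the carbonyl would.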